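Sulfonamide benzoxazoles in the malate dehydrogenase binding assay

This account rests on a few compounds, and the source may have more. Where it says the series, first, only, none or still open, it means among the compounds named here.

Measured compounds:
compound 1 `O=S(=O)(Nc1ccc2oc(-c3ccccc3)nc2c1)c1ccccc1C(F)(F)F` – > 63000 nM
compound 2 `O=S(=O)(Nc1ccc(-c2nc3ccccc3o2)cc1)c1ccc(Cl)s1` – > 63000 nM
compound 3 `O=S(=O)(Nc1ccc2oc(-c3ccccc3)nc2c1)c1ccc(F)c(C(F)(F)F)c1` – > 63000 nM

All three values come from a binding assay on isolated protein for inhibition of malate dehydrogenase, mitochondrial (Sus scrofa), with stated times of 45 min and 30 min; a lower number here means a stronger inhibitor, a higher number a weaker inhibitor. For compound 1 the value is a limit of the assay, not a number. The same holds for compound 3, whose value is also a limit. Compound 2, the starting point of the step followed here, likewise gives only a limit in this assay; it stands at the same place as the other two, and nothing separates it from them, as the limit of > 63000 nM in this assay, at which 3 of the 3 values shown sit, shows.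

Compound 4 `O=S(=O)(Nc1ccc(-c2nc3ccccc3o2)cc1)c1cccc(F)c1` has not been measured. It differs from compound 2 in one place: 3-fluorophenyl in place of 5-chlorothiophen-2-yl on a sulfonyl sulfur. The shared core of compound 2, with the sulfonamide nitrogen on it, is kept unchanged.

Going by the values given here, no step between measured compounds exists, so there is no measured change on which to build. Among the compounds with values here, the one guide is the limit of > 63000 nM in this assay, at which 3 of the 3 values shown sit. From it no step beyond the scatter is expected in this assay, in either direction: the step from compound 2 to compound 4 is estimated as a step that the limit leaves unreadable from compound 2 to compound 4. For compound 4 the value is expected to be 100000 nM, within 30000 nM to 300000 nM, most likely again reported only as a limit.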

Compound 4, half-maximal inhibitory concentration: > 63000 nM
Compound 4: no number, only a limit (the forecaster's own chance of this, stated with the estimate: 85%); the middle value does not contradict the limit.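

No step can be read from compound 2 to compound 4 in this assay, since both compounds give only a limit, not a number: the limit of > 63000 nM in this assay, at which 4 of the 4 values shown sit.

The compounds shown leave open how 3-fluorophenyl and 5-chlorothiophen-2-yl on a sulfonyl sulfur compare in this assay, and whether any change to these compounds gives a readable value there.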